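The source may report more compounds than this note shows. Statements on the series, on what has been measured and on what is new or still open speak of the compounds shown alone.

Compound 1, `COCC(COC)Nc1nc(C)nc2c(-c3ccc(OC)cc3C)c(C)nn12`, gives 9.7 nM in an assay on cell membranes for displacement of a labelled ligand from corticotropin-releasing factor receptor 1 (Rattus norvegicus); on this read-out lower numbers stand for stronger inhibition and higher numbers for weaker inhibition.
Compound 2, `COc1cc(C)c(-c2c(C)nn3c(NC4CCC4)nc(C)nc23)c(OC)c1`, gives 17.4 nM in this assay.
Compound 3, `COc1ccc(-c2c(C)nn3c(NC4CCC4)nc(C)nc23)c(C)c1`, gives 24.6 nM in this assay.

Compound 3 sits close to compound 2, with a 1.4-fold higher number from compound 2 to compound 3 (0.15 log units; within the scatter), so these two cannot be told apart. It is furthest from compound 1, with a 2.5-fold higher number from compound 1 to compound 3 (0.40 log units; beyond the scatter), a modest but real gap. Compound 4, `COc1ccc(-c2c(C)nn3c(N(CCC#N)C4CC4)nc(C)nc23)c(C)c1`, differs from compound 3 in one place: (2-cyanoethyl)(cyclopropyl)amino in place of cyclobutylamino on an aromatic carbon. Among the compounds with values here, of the two measured steps, only the one from compound 1 to compound 3 bears on this, since it also exchanges the group on that same nitrogen, and it showed that a larger, more branched group there went with a lower number in this assay. The step from compound 2 to compound 3 concerns a different part of the molecule and is not informative here. A modest step downward is therefore expected for compound 4, about a 2.1-fold lower number from compound 3 to compound 4 (0.31 log units; beyond the scatter). The estimate for compound 4 in this assay is 12 nM, with a range from 3 nM to 50 nM.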

Compound 4, half-maximal inhibitory concentration: 1.88 nM
Compound 4: the middle estimate sits 6.4-fold (0.81 log units) above what was measured; measured number outside the range, below it.
By their numbers in this assay, from the lowest: compound 4; then compounds 1, 2 and 3 (each within the scatter of the next, the first and the last beyond it).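

At this position on the shared core, replacing cyclobutylamino with (2-cyanoethyl)(cyclopropyl)amino gives a 13-fold lower number from compound 3 to compound 4 (1.12 log units; beyond the scatter) in this assay and so moves the number much further than the earlier change on this nitrogen did. The new group also outperforms the (2-methoxy-1-(methoxymethyl)ethyl)amino group with a 5.2-fold lower number from compound 1 to compound 4 (0.71 log units; beyond the scatter) and thereby shows that this position can tolerate a group with no hydrogen-bond donor, and even benefit from one. No measurement shown here explains why this change has such a large effect.

The change alters the ring and adds the 2-cyanoethyl chain in a single step, so the source of the gain remains unresolved. Cyclopropylamino, (2-cyanoethyl)(cyclobutyl)amino and a longer chain such as 3-cyanopropyl on the same nitrogen would help separate these contributions.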